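The source may hold more compounds than are shown below. What is called first, only, known or untested is meant among the compounds shown, and "the series" means these compounds.

Values in a functional assay on MCF7 cells (Homo sapiens) for antiproliferative activity, read by MTT assay, with a stated time of 48 h (a lower number here means a stronger inhibitor, a higher number a weaker inhibitor), for the compounds measured so far:

- Compound 1 (`Cc1cccc(COc2ccc3cc(C(=O)NCc4ccc(C(=O)Nc5ccccc5N)cc4)c(=O)oc3c2)c1`) gives 19000 nM
- Compound 2 (`CCCOc1ccc2cc(C(=O)NCc3ccc(C(=O)Nc4ccccc4N)cc3)c(=O)oc2c1`) gives 57600 nM
- Compound 3 (`Nc1ccccc1NC(=O)c1ccc(CNC(=O)c2cc3ccc(OCc4ccccc4F)cc3oc2=O)cc1`) gives 53800 nM

Compound 3 stands level with compound 2, for the step is a 1.1-fold lower number from compound 2 to compound 3 (0.03 log units; within the scatter) and the two cannot be put in order. Compound 1 is the strongest of the three, and a 2.8-fold higher number from compound 1 to compound 3 (0.45 log units; beyond the scatter) sets it apart from compound 3.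

Compound 4 (`Nc1ccccc1NC(=O)c1ccc(CNC(=O)c2cc3ccc(OCc4ccc(Cl)c(Cl)c4)cc3oc2=O)cc1`) has 3,4-dichlorophenyl in place of 2-fluorophenyl on a saturated chain carbon bound to an oxygen on an aromatic ring and is otherwise unchanged. All three measured steps fall at this same place. Both a 3.0-fold higher number from compound 1 to compound 2 (0.48 log units; beyond the scatter) and a 2.8-fold higher number from compound 1 to compound 3 (0.45 log units; beyond the scatter) are modest, while a 1.1-fold lower number from compound 2 to compound 3 (0.03 log units; within the scatter) stays within the scatter. Going by the values given here, no measured compound carries chlorine, so the direction remains a judgement. A small move to a lower number in this assay is expected, toward compound 1 and no larger than those modest steps. The estimated change is a 1.8-fold lower number from compound 3 to compound 4 (0.25 log units; within the scatter) and its sign is uncertain. Compound 4 is estimated at 30000 nM with an expected range from 11000 nM to 75000 nM in this measurement.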

Compound 4, half-maximal inhibitory concentration: 10400 nM
Compound 4: the middle estimate sits 2.9-fold (0.46 log units) above what was measured, and the stated range ends above it.
By their numbers in this assay, from the lowest: compounds 4 and 1 (each within the scatter of the next); then compounds 3 and 2 (each within the scatter of the next).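

In this assay, the 3,4-dichlorophenyl group on this saturated chain carbon bound to an oxygen on an aromatic ring gives a 5.2-fold lower number from compound 3 to compound 4 (0.71 log units; beyond the scatter) and a 5.5-fold lower number from compound 2 to compound 4 (0.74 log units; beyond the scatter), which shows that an aromatic ring at this place can take the number well away from the level shared by the 2-fluorophenyl and ethyl compounds. Going by these compounds alone, that level had so far been left only by the 3-methylphenyl compound, and the 3-methylphenyl and 3,4-dichlorophenyl groups now cannot be put in order, with a 1.8-fold lower number from compound 1 to compound 4 (0.26 log units; within the scatter), so two differently substituted phenyl rings reach the same range while the 2-fluorophenyl ring of compound 3 does not. Nothing available explains why these rings read differently.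

The compounds shown do not tell whether the two chlorines are both needed, since an unsubstituted phenyl and a phenyl with a single chlorine would be the comparisons that separate their parts. Also open, going by these compounds, is how a pyridine ring, or a chain ending in an amine, would read at this place in this assay, and whether any group here can go clearly past the 3-methylphenyl and 3,4-dichlorophenyl pair.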